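A few compounds are considered here, and "the series" means these few. Any claim that something is new, unique, unknown or untested is made for them only; others in the source may bear on it.

Compound 1 `C[C@H](Nc1ncnc2[nH]cnc12)c1nn(-c2cccnc2)c2cc(Cl)ccc12`: 13% in a functional assay on HepG2 cells (Homo sapiens) for inhibition, read by sulforhodamine B assay, with a stated time of 72 h, tested at 10 uM; on this read-out lower numbers stand for less inhibition and higher numbers for more inhibition at the one concentration tested (going by the name of the read-out). Compound 2 `C[C@H](Nc1ncnc2[nH]cnc12)c1nn(-c2cccc(F)c2)c2cc(F)ccc12`: 33%. Compound 3 `C[C@H](Nc1ncnc2[nH]cnc12)c1nn(-c2cccnc2)c2cc(F)ccc12`: 23%.

Compound 3 stands second highest of the three numbers. The nearest number is reached by a number 10 percentage points higher from compound 1 to compound 3 (within the scatter), the furthest by a number 10 percentage points lower from compound 2 to compound 3 (within the scatter), so all three lie within the scatter of one another. Compound 4 `C[C@H](Nc1ncnc2[nH]cnc12)c1nn(-c2ccc(C#N)cc2)c2cc(F)ccc12` differs from compound 3 by 4-cyanophenyl in place of pyridin-3-yl on an aromatic nitrogen. The step that bears on this is the earlier exchange of the aryl group on the same aromatic nitrogen, a number 10 percentage points lower from compound 2 to compound 3 (within the scatter), which stayed within the scatter. In this assay compound 4 is therefore expected to give no step beyond the scatter, a number 7 percentage points higher from compound 3 to compound 4 (within the scatter). The estimate for compound 4 is 30%, within a range from 10% to 50%.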

Compound 4, a percentage reported as inhibition, at one concentration (the size of the read-out at that concentration, not a potency): 57%
The estimate for compound 4 lay 27 percentage points below the measured number; the whole stated range lies below it.
By their numbers in this assay, from the lowest: compounds 1, 3 and 2 (each within the scatter of the next, the first and the last beyond it); then compound 4.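

In this assay the entry of 4-cyanophenyl on the aromatic nitrogen brings a number 34 percentage points higher from compound 3 to compound 4 (beyond the scatter) and a number 24 percentage points higher from compound 2 to compound 4 (beyond the scatter) against pyridin-3-yl and 3-fluorophenyl. This position can therefore move the number beyond the scatter, which the earlier exchange of aryl groups there had not shown. Nothing available explains the step.

From the compounds shown here alone, whether the nitrile or the carbon-only ring carries the step remains open, as does how an unsubstituted phenyl, or a carboxylic acid or an amide in place of the nitrile, would read. Also open, going by these compounds, is whether the step holds with chloro in place of fluoro on the core.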